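Resolving a Racemate: One Enantiomer of Compound 2

This account rests on a few compounds, and the source may have more. Where it says the series, first, only, none or still open, it means among the compounds named here.

Going by the values given here, compound 2 `CCc1ccc2[nH]c(=O)c(CN(Cc3ccc(C(C)(C)C)cc3)C(C)c3ccc(F)cc3)cc2c1` carries the only numeric reading here: in a toxicity assay on MDCK cells (Canis lupus familiaris) for cytotoxicity, read by crystal violet staining, with a stated time of 48 h (on this read-out lower numbers stand for higher toxicity in this test and higher numbers for lower toxicity in this test), compound 2 gives 2800 nM. Compound 1 `CCc1ccc2[nH]c(=O)c(CN(CCCO)Cc3ccc(C(C)(C)C)cc3)cc2c1` reaches only a limit of the assay, giving > 10000 nM in this assay. The step of an at least 3.5-fold lower number from compound 1 to compound 2 (0.55 log units; beyond the scatter) swaps a different group and does not speak to the change ahead. Compound 3 `CCc1ccc2[nH]c(=O)c(CN(Cc3ccc(C(C)(C)C)cc3)[C@@H](C)c3ccc(F)cc3)cc2c1` differs from compound 2 as follows: the two compounds have the same atoms and bonds; at least one stereo element is drawn with a configuration in one of them and without one in the other: 1 of 1 stereo elements differ; a stereocentre at a saturated chain carbon is drawn without a configuration in compound 2 and S in compound 3. Among the compounds with values here, no measured step here separates a racemate from a single enantiomer, so no shift beyond the scatter is expected, and the estimate for compound 3 is 2800 nM (range 1000 nM to 8000 nM), an expected step of no change at the digits printed from compound 2 to compound 3 (within the scatter).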

Compound 3, half-maximal cytotoxic concentration: > 5000 nM
Compound 3: no number, only a limit; the forecaster's own chance of this, stated with the estimate: 15%; at least 1.7-fold (0.25 log units) between middle value and limit.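

Drawing the stereocentre as S gives the first reading of a defined configuration at this carbon: in this assay, compound 3 gives > 5000 nM, which is a limit and not a number. The result is an at least 1.7-fold higher number from compound 2 to compound 3 (0.25 log units; that floor lies within the scatter), so the S form may be less toxic in this test, but this is not established. Compound 1 and compound 3 both stand at limits, and the step between them cannot be read.

From the compounds shown here alone, the reading for the R form remains open. So does the effect of chlorine in place of the fluorine on the 1-(4-fluorophenyl)ethyl group.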